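From an Undefined to a Defined Pair of Ring Stereocentres

The source may report more compounds than this note shows. Statements on the series, on what has been measured and on what is new or still open speak of the compounds shown alone.

Measured so far in a functional assay on HEK293 cells for antagonist activity at metabotropic glutamate receptor 5 (Homo sapiens), read by FLIPR and calcium flux; on this read-out lower numbers stand for stronger inhibition and higher numbers for weaker inhibition:
- compound 1 `N#Cc1cccc(C(=O)NC2CCCC(NC(=O)c3ccccn3)C2)c1`: 531 nM
- compound 2 `CN(C)c1ccc(C(=O)N[C@H]2CCC[C@H](NC(=O)c3cccc(Cl)c3)C2)cc1`: 473 nM
- compound 3 `O=C(NC1CCCC(NC(=O)c2ccccn2)C1)c1cccc(Cl)c1`: 314 nM

Compound 3 gives the lowest of the three numbers in this assay, but its nearest neighbour, compound 2, and the furthest, compound 1, both sit within the scatter of it, so no order among the three can be claimed. Among the compounds with values here, the one measured step that reaches compound 3 is a 1.7-fold lower number from compound 1 to compound 3 (0.23 log units; within the scatter), a change of substituent rather than of configuration.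

Compound 4 `O=C(N[C@@H]1CCC[C@H](NC(=O)c2ccccn2)C1)c1cccc(Cl)c1` keeps every atom and bond of compound 3; the change is the two compounds have the same atoms and bonds; at least one stereo element is drawn with a configuration in one of them and without one in the other: 2 of 2 stereo elements differ; a stereocentre at a saturated ring carbon is drawn without a configuration in compound 3 and R in compound 4; a stereocentre at a saturated ring carbon is drawn without a configuration in compound 3 and S in compound 4. Within the data shown here, no measured step addresses a configuration alone. Compound 2 is drawn with defined stereocentres and compound 3 without, yet their values lie within the scatter, which is the only hint available and it speaks of no large effect. A single drawn isomer could give either a lower or a higher number than the undefined drawing, and the size of that shift cannot be read from the data. The step from compound 3 to compound 4 is therefore expected to be a 1.3-fold lower number from compound 3 to compound 4 (0.10 log units; within the scatter), with a wide range. For compound 4 the estimate in this assay is 250 nM, between 80 nM and 1000 nM.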

Compound 4, half-maximal inhibitory concentration: 1510 nM
Compound 4: the middle estimate sits 6.0-fold (0.78 log units) below what was measured; the whole stated range lies below it.
By their numbers in this assay, from the lowest: compounds 3, 2 and 1 (each within the scatter of the next); then compound 4.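

In this assay the drawing of the two ring stereocentres proves able to shift the read-out: going to a single defined configuration gives a 4.8-fold higher number from compound 3 to compound 4 (0.68 log units; beyond the scatter) with no atom or bond changing. Within the data shown here, the one earlier step, a change of substituent, stayed within the scatter, so this is the first change in the set seen to move the number beyond it. All that separates this pair is the stereo drawing: the fact that one of compounds 3 and 4 is drawn with a defined configuration and the other without, at the place where they differ.

On these data alone, whether another defined configuration at these two ring carbons gives a lower number than compound 3 remains open. Also open, as far as these compounds go, is whether the same dependence on configuration holds with a methoxy group in place of the chloro.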